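A few compounds are considered here, and "the series" means these few. Any claim that something is new, unique, unknown or untested is made for them only; others in the source may bear on it.

Measured compounds: compound 1 `C[C@@H](NC(=O)c1ccc(C#Cc2ccccc2)cn1)C(C)(C)O` gives 43.2% in an ADME assay on HEK293 cells for agonist activity at metabotropic glutamate receptor 5 (Rattus norvegicus), read by fluorescence and calcium flux; on this read-out higher numbers stand for larger maximal responses and lower numbers for smaller maximal responses; compound 2 `C[C@@H](NC(=O)c1ccc(C#Cc2ccc(F)cc2F)cn1)C(C)(C)O` gives 38.2% in this assay; compound 3 `CC(C)[C@@H](C)NC(=O)c1ccc(C#Cc2cccc(F)c2)cn1` gives 22.5% in this assay.

Compound 3 has the lowest of the three values: compound 2 lies nearer to it and compound 1 further away, and both gaps are beyond the scatter.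

Compound 4 `CC(C)(O)CNC(=O)c1ccc(C#Cc2cccc(F)c2)cn1` is not yet measured. It differs from compound 3 in one place: 2-hydroxy-2-methylpropyl in place of 1,2-dimethylpropyl on an amide-type nitrogen. For the measured compounds named here, no measured pair shows exactly this change. Going by the values given here, the only measured step, a number 5 percentage points lower from compound 1 to compound 2 (within the scatter), concerns the substituent on the triple-bonded carbon and lies within the scatter, so it says little about the amide nitrogen. Compounds 1 and 2, which differ from compound 3 in more than one place, both stand well above compound 3, and their own step shows the ring change contributing little. This points, weakly, toward the amide side chain as the part that matters, so a moderate rise is expected for compound 4 in this assay, about a number 11.5 percentage points higher from compound 3 to compound 4 (beyond the scatter), though with wide uncertainty. Compound 4 is therefore expected to give 34%, within a range of 20% to 48%.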

Compound 4, largest response reached (reported as efficacy), in percent of the reference or control that the assay uses: 20%
Estimate against measurement, compound 4: 14 percentage points above; low and high end bracket the measured number.
By their numbers in this assay, from the lowest: compounds 4 and 3 (each within the scatter of the next); then compounds 2 and 1 (each within the scatter of the next).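

In this assay there is a number 2.5 percentage points lower from compound 3 to compound 4 (within the scatter), so on an amide-type nitrogen 2-hydroxy-2-methylpropyl and 1,2-dimethylpropyl cannot be told apart here, even though the entering group brings a hydrogen-bond donor and a hydrogen-bond acceptor that the leaving group lacks, and the defined stereocentre of the leaving group is gone. For the compounds shown here, the only earlier step concerned the substituent on the triple-bonded carbon, whereas this pair changes the group on the amide-type nitrogen alone and keeps the rest of the molecule the same. Nothing measured here gives a reason for this result.

Going by these compounds, it remains open whether an amine or a carboxylic acid in place of the hydroxyl, or a longer chain on the amide-type nitrogen, would move the response beyond the scatter. Compounds 1 and 2 differ from compound 3 and compound 4 in more than one place, so the compounds shown also leave open whether these two side chains would stay this close with phenyl or 2,4-difluorophenyl on the triple-bonded carbon.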